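An Amino Group on the Carboxyphenyl of Compound 1

This account rests on a few compounds, and the source may have more. Where it says the series, first, only, none or still open, it means among the compounds named here.

Compound 1 `O=C(O)c1ccc(CN2CCC[C@H](O[C@H](CO)c3cc(Cl)cc(Cl)c3)[C@@H]2c2ccccc2)cc1`: 77000 nM
Compound 2 `CC(=O)NS(=O)(=O)c1ccc(CN2CCC[C@H](O[C@H](CO)c3cc(Cl)cc(Cl)c3)[C@@H]2c2ccccc2)cc1`: > 200000 nM

In an assay on isolated protein for activation of cGMP-dependent protein kinase 1 (Homo sapiens), read by ADP-Glo, with stated times of 30 min and 2 h (on this read-out higher numbers stand for an effect only at larger amounts of compound and lower numbers for an effect already at smaller amounts), compound 1 gives 77000 nM, the only plain number shown. For compound 2 the result is a limit of the method, (the limit of > 200000 nM in this assay, at which 1 of the 2 values shown sits). Among the compounds with values here, the single measured step, an at least 2.5-fold higher number from compound 1 to compound 2 (0.41 log units; beyond the scatter), replaces the carboxy group and leaves the rest of the carboxyphenyl untouched, so it says little about the change at hand. Compound 3 `Nc1cc(C(=O)O)ccc1CN1CCC[C@H](O[C@H](CO)c2cc(Cl)cc(Cl)c2)[C@@H]1c1ccccc1` differs from compound 1 by amino in place of hydrogen on an aromatic carbon. Within the data shown here, with no measured step touching this position, only a small change is expected, no change at the digits printed from compound 1 to compound 3 (within the scatter). Compound 3 is therefore estimated at 77000 nM, within 30000 nM to 200000 nM.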

Compound 3, half-maximal effective concentration in the cGMP-dependent protein kinase 1 assay: 168000 nM
Compound 3: the middle estimate sits 2.2-fold (0.34 log units) below what was measured; the measured number falls inside the stated range.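

This position on the carboxyphenyl is not silent: in the cGMP-dependent protein kinase 1 assay, compound 3 gives 168000 nM, and the amino group brings a 2.2-fold higher number from compound 1 to compound 3 (0.34 log units; beyond the scatter), so compound 3 needs a larger amount of compound for the same effect. In a physicochemical assay for solubility, at pH 7 (on this read-out higher numbers stand for higher solubility and lower numbers for lower solubility), compound 1 gives 85000 nM and compound 3 gives 78000 nM; the same change brings a 1.1-fold lower number from compound 1 to compound 3 (0.04 log units; within the scatter), so the two solubility values do not separate. Nothing measured here says why the amino group has this effect on activation.

As far as these compounds go, whether a smaller group such as fluorine or methyl in the same place would move the activation number in the same way remains open.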